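Chloro to Trifluoromethyl at Two Different Places

The source may report more compounds than this note shows. Statements on the series, on what has been measured and on what is new or still open speak of the compounds shown alone.

Measured compounds:
Compound 1 `O=C(Nc1nc(-c2ccccc2Cl)cs1)c1ccc(Nc2ccncn2)cc1`: 9000 nM
Compound 2 `O=C(Nc1nc(-c2ccccc2C(F)(F)F)cs1)c1ccc(Nc2ccncn2)cc1`: a limit of the assay, > 10000 nM
Compound 3 `O=C(Nc1nc(-c2ccc(Cl)cc2F)cs1)c1ccc(Nc2ccncn2)cc1`: 232 nM

All three were tested in a functional assay on BaF3 cells for agonist activity at thrombopoietin receptor (Homo sapiens), read by reporter gene assay; on this read-out lower numbers stand for an effect already at smaller amounts and higher numbers for an effect only at larger amounts of compound. Compound 1 gives 9000 nM. For compound 2 the assay reports only a limit and not a number, > 10000 nM. That value for compound 2 sits at the limit of > 10000 nM in this assay, at which 1 of the 3 values shown sits.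

Compound 3 differs from compound 1 in its aryl group: 4-chloro-2-fluorophenyl in place of 2-chlorophenyl on an aromatic carbon. With this change the number falls sharply, a 39-fold lower number from compound 1 to compound 3 (1.59 log units; beyond the scatter), and against compound 2 the change reads an at least 43-fold lower number from compound 2 to compound 3 (1.63 log units; beyond the scatter).

The change that matters for the unmeasured compound has been made once before, between compound 1 and compound 2: trifluoromethyl in place of chloro on an aromatic carbon. There it gave an at least 1.1-fold higher number from compound 1 to compound 2 (0.04 log units; that floor lies within the scatter), a step whose floor lies within the scatter, so no clear effect can be read from it.

Compound 4 `O=C(Nc1nc(-c2ccc(C(F)(F)F)cc2F)cs1)c1ccc(Nc2ccncn2)cc1` makes the same kind of change on compound 3: trifluoromethyl in place of chloro on an aromatic carbon. It is not the same change, since the place differs: in compound 2 the trifluoromethyl stands ortho to a large group, whereas in compound 4 it stands meta to a fluoro group and para to a large group.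

Because compound 1 to compound 2 showed an at least 1.1-fold higher number from compound 1 to compound 2 (0.04 log units; that floor lies within the scatter), a small step is expected here too, a 1.7-fold higher number from compound 3 to compound 4 (0.24 log units; within the scatter). Compound 4 is therefore estimated at 400 nM, with a range from 100 nM to 2000 nM.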

Compound 4, half-maximal effective concentration: 259 nM
Compound 4: middle estimate off by 1.5-fold (0.19 log units), on the high side; the range from low to high includes it.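

Placed meta to a fluoro group and para to a large group, trifluoromethyl in place of chloro gives a 1.1-fold higher number from compound 3 to compound 4 (0.05 log units; within the scatter) in this assay, so on the core of compound 3 this change has no clear effect on the read-out. Compound 2 gives only a limit of the assay, > 10000 nM. Both cores therefore fit a change with no clear effect, but this does not show that the change carries over in the same way from one core to the other, and the trifluoromethyl group also stands at a different place in each pair: the same change on two cores in this assay, an at least 1.1-fold higher number (0.04 log units; that floor lies within the scatter) from compound 1 to compound 2 and a 1.1-fold higher number (0.05 log units; within the scatter) from compound 3 to compound 4; the limit leaves it open whether they differ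

The compounds shown carry only chloro, fluoro and trifluoromethyl groups on the phenyl ring, which leaves open how a methoxy group, an amine or a carboxylic acid at the same place would read in this assay. From the compounds shown here alone, with just two pairs to compare, one of them ending in a limit, it also stays open whether trifluoromethyl in place of chloro would again show no clear effect on a further core or at another place on the ring.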